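Alpha glucosidase series: moving a halogen around the aryl ring

The source may hold more compounds than are shown below. What is called first, only, known or untested is meant among the compounds shown, and "the series" means these compounds.

Compound 3 `O=C1/C(=C/c2ccccc2)CCC/C1=C\c1ccccc1Cl` gives 43% in an assay on isolated protein for inhibition of Alpha glucosidase (Homo sapiens), with stated times of 5 min and 15 min, tested at 50 uM; on this read-out higher numbers stand for more inhibition at the one concentration tested (going by the name of the read-out) and lower numbers for less inhibition. Going by the values given here, on the numbers so far it stands highest of the three measured compounds, but only its gap to compound 1 is beyond the scatter; compound 2 sits within the scatter of it. Compound 1 `O=C1/C(=C/c2ccccc2)CCC/C1=C\c1ccc(Cl)cc1` gives 27.6% in this assay, and compound 2 `Cc1ccc(/C=C2\CCC/C(=C\c3ccccc3)C2=O)cc1` gives 34.1% in this assay.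

Compound 4 `O=C1/C(=C/c2ccccc2)CCC/C1=C\c1cccc(Br)c1` is not yet measured. Against compound 3 the change is 3-bromophenyl in place of 2-chlorophenyl on a double-bonded chain carbon bound to a double-bonded ring carbon.

Among the compounds with values here, two measured steps bear on this. Moving the chloro around the aryl ring gave a number 15.4 percentage points higher from compound 1 to compound 3 (beyond the scatter), so the position of the halogen on that ring is not indifferent. Swapping a 4-methylphenyl for the 2-chlorophenyl gave a number 8.9 percentage points higher from compound 2 to compound 3 (within the scatter), and methyl for chloro gave a number 6.5 percentage points higher from compound 1 to compound 2 (within the scatter). Within the data shown here, no measured compound carries a 3-bromophenyl, so there is no direct precedent for either the bromo or its new place.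

Given that the 2-chlorophenyl of compound 3 sits at the top of the set and that its only step beyond the scatter is a number 15.4 percentage points higher from compound 1 to compound 3 (beyond the scatter), compound 4 is expected to give 33% in this assay, in the range 20% to 46%. That estimate corresponds to an expected step of a number 10 percentage points lower from compound 3 to compound 4 (within the scatter), a modest move downward that could still fall within the scatter.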

Compound 4, a percentage reported as inhibition, at one concentration (the size of the read-out at that concentration, not a potency): 27.2%
The estimate for compound 4 lay 5.8 percentage points above the measured number; measured number inside the range.
By their numbers in this assay, from the lowest: compounds 4, 1, 2 and 3 (each within the scatter of the next, the first and the last beyond it).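

In this assay the step from 2-chlorophenyl to 3-bromophenyl at this place, on a double-bonded chain carbon bound to a double-bonded ring carbon, gives a number 15.8 percentage points lower from compound 3 to compound 4 (beyond the scatter) and is the second step beyond the scatter in the series, so the separation of compound 3 no longer rests on compound 1 alone. The other two new readings are a number 6.9 percentage points lower from compound 2 to compound 4 (within the scatter) and a number 0.4 percentage points lower from compound 1 to compound 4 (within the scatter), which leave 3-bromophenyl, 4-chlorophenyl and 4-methylphenyl unresolved from one another at this place, while compound 3 stands clear of compound 1 and compound 4 but still not of compound 2. Nothing available accounts for the difference between the 2-chlorophenyl and the 3-bromophenyl.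

The halogen and its ring position change together from compound 3 to compound 4, and no pair shown carries bromo and chloro at the same ring position, so the share of each in that step stays open. Also open, on these data alone, is how this place responds to groups outside the halogen and methyl set, such as a methoxy, an amine or a carboxylic acid on the aryl ring.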